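A Smaller Ring on the Amide Nitrogen

A few compounds are considered here, and "the series" means these few. Any claim that something is new, unique, unknown or untested is made for them only; others in the source may bear on it.

Measured compounds:
compound 1 `CCC(C)C(NC(=O)n1nnc2ccccc21)C(=O)NC1CCCCC1` — 98000 nM
compound 2 `CCC(C)C(NC(=O)NO)C(=O)NC(c1ccccc1)c1ccccc1` — 56000 nM

In a functional assay on MOLT-4 cells (Homo sapiens) for inhibition (on this read-out lower numbers stand for stronger inhibition and higher numbers for weaker inhibition), compound 1 gives 98000 nM, and compound 2 gives 56000 nM; the two numbers lie within the usual scatter of each other, so neither can be ranked against the other. Going by the values given here, no step between measured compounds is available to guide a forecast. Compound 3 `CCC(C)C(NC(=O)n1nnc2ccccc21)C(=O)NC1CCCC1` differs from compound 1 by cyclopentyl in place of cyclohexyl on an amide-type nitrogen. Since nothing measured speaks to this change, only a step within the scatter is expected, in no particular direction, as a 1.1-fold lower number from compound 1 to compound 3 (0.04 log units; within the scatter). Compound 3 is therefore expected to give about 90000 nM in this assay, within 30000 nM to 300000 nM.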

Compound 3, half-maximal inhibitory concentration: 94000 nM
Compound 3: the middle estimate sits 1.0-fold (0.02 log units) below what was measured; the range from low to high includes it.
By their numbers in this assay, from the lowest: compounds 2, 3 and 1 (each within the scatter of the next).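

In this assay, going by these compounds alone, the swap of cyclohexyl for cyclopentyl on the amide-type nitrogen gives a 1.0-fold lower number from compound 1 to compound 3 (0.02 log units; within the scatter) and so offers the first direct reading at this position: with one ring size exchanged for the other, the two compounds cannot be told apart. Nothing available explains this result. On these data alone, whether this position tolerates any group remains open, since both groups are rings of carbon only of similar size. A straight hexyl chain, or a cyclohexyl ring carrying an amine or a carboxylic acid, could still tell more.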